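This account rests on a few compounds, and the source may have more. Where it says the series, first, only, none or still open, it means among the compounds named here.

Compound 3 `CC(C)n1cc(-c2ccnc3[nH]c(C4CCN(CC(=O)N5CCCCC5)CC4)cc23)ccc1=O` gives the highest number of the three in a physicochemical assay for lipophilicity, using the shake flask method, measured as octanol-water partition, at pH 7.4 (a higher number here means a more lipophilic compound, a lower number a more polar compound), at 2.8. Compound 2 `CC(C)n1nc(-c2ccnc3[nH]c(C4CCN(CC(=O)N(C)C)CC4)cc23)ccc1=O` gives 2 in this assay, and compound 1 `CN(C)C(=O)CN1CCC(c2cc3c(-c4ccc(=O)n(C5CCC5)c4)ccnc3[nH]2)CC1` gives 1.9; both values lie beyond the scatter below that of compound 3. Compound 4 `CNC(=O)CN1CCC(c2cc3c(-c4ccc(=O)n(C(C)C)c4)ccnc3[nH]2)CC1` differs from compound 3 in the amide part: methylamino in place of piperidin-1-yl on a carbonyl carbon. Going by the values given here, no direct step between measured compounds matches this change, but compound 2, which carries a smaller amide substituent, gives 2, a clear drop from compound 3. A downward step of similar or greater size is therefore expected in this assay, as the move from compound 3 to compound 4 is estimated at a number 1.20 log units lower from compound 3 to compound 4 (beyond the scatter). Compound 4 is expected to give about 1.6 in this assay, within a range from 1.1 to 2.1.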

Compound 4, distribution coefficient: 2.2
For compound 4 the middle estimate is 0.60 log units below the measured one, and the stated range ends below it.
By their numbers in this assay, from the lowest: compounds 1, 2 and 4 (each within the scatter of the next); then compound 3.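

In this assay, going by these compounds alone, methylamino in place of piperidin-1-yl on a carbonyl carbon gives a number 0.60 log units lower from compound 3 to compound 4 (beyond the scatter) as the first direct reading of a change at this position. The change takes away a six-membered non-aromatic ring and brings in one hydrogen-bond donor, so the two features change together and this single step cannot separate them. No measurement shown explains the size of the step. The compounds shown leave open how this assay's number would respond to morpholin-4-yl or a plain amino group on the same carbonyl carbon, with the rest of compound 3 unchanged.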